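The compounds below may be only part of what the source reports. "The series", "measured", "known", "first", "only" and "open" are said of these compounds alone.

Compound 1 `CCn1cc(C(=O)C(=O)Nc2ccc(OC)nc2)c2ccccc21`: 219 nM
Compound 2 `CCC(C)n1cc(C(=O)C(=O)Nc2ccc(OC)nc2)c2ccccc21`: 68 nM

In a functional assay on FaDu cells (Homo sapiens) for cytotoxicity, read by MTT assay, with a stated time of 72 h (on this read-out lower numbers stand for higher toxicity in this test and higher numbers for lower toxicity in this test), compound 2 gives 68 nM and holds the lower of the two numbers, while compound 1 gives 219 nM on the same read-out. Within the data shown here, the one measured step, a 3.2-fold lower number from compound 1 to compound 2 (0.51 log units; beyond the scatter) in this test, is modest but beyond the scatter, and it lies in the chain on the aromatic nitrogen.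

Compound 3 `COc1ccc(NC(=O)C(=O)c2cn(CCOC(C)C)c3ccccc23)cn1` has not been measured. Its difference from compound 2 is 2-isopropoxyethyl in place of sec-butyl on an aromatic nitrogen and falls on that same aromatic nitrogen. Among the measured compounds shown here, no measured compound carries an oxygen in this chain, so the direction is uncertain. A step no larger than the measured one is expected, more likely toward a higher number. The expected change is small, estimated as a 1.5-fold higher number from compound 2 to compound 3 (0.17 log units; within the scatter) and probably within the scatter. Compound 3 is estimated at 100 nM (expected range 35 nM to 300 nM).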

Compound 3, concentration lethal to 50% of the cells: 211 nM
Estimate against measurement, compound 3: 2.1-fold (0.32 log units) below, within the range that was stated.
By their numbers in this assay, from the lowest: compound 2; then compounds 3 and 1 (each within the scatter of the next).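

Among these compounds, with 2-isopropoxyethyl, the aromatic nitrogen carries an oxygen-bearing chain for the first time, and in this assay the result is a 3.1-fold higher number from compound 2 to compound 3 (0.49 log units; beyond the scatter), opposite in direction to a 3.2-fold lower number from compound 1 to compound 2 (0.51 log units; beyond the scatter). Set against the shorter chain, the same change gives a 1.0-fold lower number from compound 1 to compound 3 (0.02 log units; within the scatter), which lies within the scatter, so a larger chain on this nitrogen does not by itself go with a lower number in these three compounds. Nothing available here explains why sec-butyl and 2-isopropoxyethyl part in this way.

The three chains leave open whether the oxygen, the chain length or the branching governs the number, since 2-isopropoxyethyl differs from sec-butyl in more than one of these. A plain pentyl chain, or a chain ending in a hydroxyl group or an amine, would remain to be compared at this position.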